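The source may report more compounds than this note shows. Statements on the series, on what has been measured and on what is new or still open speak of the compounds shown alone.

Measured in a functional assay on A549 cells (Homo sapiens) for antiproliferative activity, read by sulforhodamine B assay, with a stated time of 3 days; a lower number here means a stronger inhibitor of growth, a higher number a weaker inhibitor of growth:
- compound 1 `COCC(=O)Nc1cccc(Nc2ncc(F)c(Nc3ccc(F)cc3)n2)c1`: 2050 nM
- compound 2 `Cn1ccnc1NC(=O)c1cccc(Nc2ncc(F)c(Nc3ccc(F)cc3)n2)c1`: 10100 nM

Compound 2, at 10100 nM, is the weaker growth inhibitor of the two. Among the compounds with values here, the only measured step is a 4.9-fold higher number from compound 1 to compound 2 (0.69 log units; beyond the scatter). Compound 3 `CN(C)CC(=O)Nc1cccc(Nc2ncc(F)c(Nc3ccc(F)cc3)n2)c1` has (((dimethylamino)methyl)carbonyl)amino in place of (1-methyl-1H-imidazol-2-yl)carbamoyl on an aromatic carbon. On these data alone, the new group resembles the ((methoxymethyl)carbonyl)amino of compound 1, so this change should largely undo a 4.9-fold higher number from compound 1 to compound 2 (0.69 log units; beyond the scatter), though swapping methoxy for dimethylamino remains untested. The expected change is a 5.1-fold lower number from compound 2 to compound 3 (0.70 log units; beyond the scatter). For compound 3 the estimated value is 2000 nM, within a range of 600 nM to 6500 nM.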

Compound 3, concentration for 50% growth inhibition: 1180 nM
Beside the measured number, compound 3's estimate is 1.7-fold (0.23 log units) above it, and the stated range covers the measured number.
By their numbers in this assay, from the lowest: compounds 3 and 1 (each within the scatter of the next); then compound 2.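

In this assay, the ringless (((dimethylamino)methyl)carbonyl)amino in place of (1-methyl-1H-imidazol-2-yl)carbamoyl gives an 8.6-fold lower number from compound 2 to compound 3 (0.93 log units; beyond the scatter), so a second open-chain group at this position also sits clear of compound 2. Dimethylamino in place of methoxy gives a 1.7-fold lower number from compound 1 to compound 3 (0.24 log units; within the scatter), so this swap on the chain separates neither compound from the other. Nothing measured here explains either step.

The compounds shown do not separate the loss of the ring from the turned amide link. On these data alone, how a longer chain or a morpholine on the chain would compare also stays open.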